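The source may report more compounds than this note shows. Statements on the series, on what has been measured and on what is new or still open speak of the compounds shown alone.

Compound 1 `O=S(=O)(c1ccccc1)C1(CCCN2CCCCC2)CCC1` gives 2700 nM in an assay on CHO cells for displacement of a labelled ligand from 5-hydroxytryptamine receptor 7 (Homo sapiens); a lower number here means a stronger inhibitor, a higher number a weaker inhibitor.
Compound 2 `CN1CCN(CCCC2(S(=O)(=O)c3ccccc3)CCC2)CC1` gives 5800 nM in this assay.
Compound 3 `O=S(=O)(c1ccccc1)C1(CCCN2CCN(c3ccccc3)CC2)CCC1` gives 22 nM in this assay.

Among these three numbers compound 1 stands second highest: compound 2 is its nearest neighbour, with a 2.1-fold higher number from compound 1 to compound 2 (0.33 log units; beyond the scatter), and compound 3 its furthest, a much lower number. Compound 4 `O=S(=O)(c1ccccc1)C1(CCCN2CCC(c3ccccc3)CC2)CCC1` differs from compound 1 by phenyl in place of hydrogen on a saturated ring carbon. The step that bears on it is the one in which a phenyl also enters the same six-membered ring, there on the nitrogen, giving a 260-fold lower number from compound 2 to compound 3 (2.42 log units; beyond the scatter). Compound 3 against compound 1 likewise shows a far lower number. On that basis a large fall in this assay is expected for compound 4, though the phenyl now sits on a carbon rather than the nitrogen, so the expected step is set at a 23-fold lower number from compound 1 to compound 4 (1.35 log units; beyond the scatter). Compound 4 is therefore estimated at 120 nM, between 25 nM and 600 nM.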

Compound 4, inhibition constant: 26 nM
For compound 4 the middle estimate is 4.6-fold (0.66 log units) above the measured one, within the range that was stated.
By their numbers in this assay, from the lowest: compounds 3 and 4 (each within the scatter of the next); then compound 1; then compound 2.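

In this assay, phenyl in place of hydrogen on a saturated ring carbon, three ring bonds from the ring nitrogen, gives a 100-fold lower number from compound 1 to compound 4 (2.02 log units; beyond the scatter) and so shows that a large step does not require the phenyl to stand on a ring nitrogen. Compound 4 gives 26 nM and compound 3 gives 22 nM and these values lie within the scatter of each other. No measurement given here accounts for this step. As far as these compounds go, whether a benzyl or a pyridyl in place of this phenyl would hold the number stays open, as does the effect of a longer chain to the ring nitrogen.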